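The compounds below may be only part of what the source reports. "The series", "measured", "known", "first", "only" and "open" are said of these compounds alone.

Measured so far in a functional assay on SK-OV-3 cells (Homo sapiens) for cytotoxicity; on this read-out higher numbers stand for an effect only at larger amounts of compound and lower numbers for an effect already at smaller amounts:
compound 1 `C=CCCCCCCCC#CC#C/C=C\C(C)=O` — 45.1 ug/mL
compound 2 `CCCCCCCC#CC#C/C=C\C(C)=O` — 25.9 ug/mL
compound 3 `CCCCCCCC#CC#CC1CC(=O)C=C(C)C1` — 29.2 ug/mL

Compound 1 stands at the top of these three numbers as written, yet all three lie within the usual scatter of one another, so no real separation is shown. Going by the values given here, the only single-point step, a 1.7-fold lower number from compound 1 to compound 2 (0.24 log units; within the scatter), concerns the chain end and stays within the scatter.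

Compound 4 `C=CCCCCCCCC#CC#C/C=C/C(C)=O` differs from compound 1 as follows: the two compounds have the same atoms and bonds and differ only in configuration as drawn: 1 of 1 stereo elements differ; a double bond is drawn Z in compound 1 and E in compound 4. Among the compounds with values here, no measured step in this assay touches the configuration of that double bond, so nothing here bears directly on the change; the one step available, from compound 1 to compound 2, shows how little the series has moved so far. The expectation is therefore a 1.0-fold lower number from compound 1 to compound 4 (0.00 log units; within the scatter), nothing beyond the scatter. Compound 4 is estimated at 45 ug/mL, with a range from 20 ug/mL to 100 ug/mL.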

Compound 4, concentration for half-maximal effect: 2.5 ug/mL
Estimate against measurement, compound 4: 18-fold (1.26 log units) above; the measured number lies below the stated range.
By their numbers in this assay, from the lowest: compound 4; then compounds 2, 3 and 1 (each within the scatter of the next).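

In this assay, the configuration of this double bond is what moves the number beyond the scatter: the change from Z to E gives an 18-fold lower number from compound 1 to compound 4 (1.26 log units; beyond the scatter), whereas the chain-end change gave only a 1.7-fold lower number from compound 1 to compound 2 (0.24 log units; within the scatter). The gap belongs to that double bond alone, because nothing else separates the pair: the fact that compounds 1 and 4 differ only in the configuration as drawn

On these data alone, whether the same change from Z to E gives a step of this size on the shorter chain of compound 2 remains open. So does whether compound 4 keeps its low number with a carboxylic acid in place of the ketone carbonyl.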